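The source may report more compounds than this note shows. Statements on the series, on what has been measured and on what is new or still open speak of the compounds shown alone.

Compound 2 `Nc1cc(N)c2nc(-c3ccccc3)c(NCc3ccc(F)cc3)nc2c1` is tested in a functional assay on 786-0 cells (Homo sapiens) for inhibition, read by sulforhodamine B assay, with a stated time of 48 h; a lower number here means that less compound is tolerated, a higher number that more compound is tolerated. In this assay compound 2 gives < 100000 nM, which is a limit of the assay rather than a number. Compound 1 `Nc1cc(N)c2nc(-c3ccccc3)c(Sc3ccc(F)cc3)nc2c1` gives < 100000 nM in this assay, again a limit. For the measured compounds named here, the step that the two limits leave unreadable from compound 1 to compound 2 therefore cannot be read, and it is the only measured step that bears on the change to compound 3 `COc1ccc(Sc2nc3cc(N)cc(N)c3nc2-c2ccccc2)cc1`; that change is (4-methoxyphenyl)sulfanyl in place of (4-fluorobenzyl)amino on an aromatic carbon. The shared limit of < 100000 nM in this assay, at which 2 of the 2 values shown sit, offers no direction or size to expect. For compound 3 the estimate is 30000 nM, between 5000 nM and 100000 nM. The expected step that the limit leaves unreadable from compound 2 to compound 3 is thus small.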

Compound 3, concentration lethal to 50% of the cells: 70800 nM
Estimate against measurement, compound 3: 2.4-fold (0.37 log units) below, and the stated range covers the measured number.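

Compound 1 and compound 2 carry only limits of the assay, not numbers, so no step from either of them to compound 3 can be read: the limit of < 100000 nM in this assay, at which 2 of the 3 values shown sit.

The compounds shown leave open how far either change, methoxy in place of fluoro or (4-methoxyphenyl)sulfanyl in place of (4-fluorobenzyl)amino, moves the value.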